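Swapping Sulfur for Selenium in a Shared Core

The compounds below may be only part of what the source reports. "The series", "measured", "known", "first", "only" and "open" are said of these compounds alone.

Measured so far, in a functional assay on CCRF-CEM cells (Homo sapiens) for cytotoxicity, read by MTT assay, with a stated time of 72 h; a higher number here means that more compound is tolerated, a lower number that less compound is tolerated:
Compound 1 `C[Se]c1nc(NCc2ccccc2)c2ccccc2n1`: compound 1 gives 83500 nM.
Compound 2 `CSc1nc(NCc2ccccc2)c2ccccc2n1`: compound 2 reaches only the assay limit, > 100000 nM.
Compound 3 `CSc1ccc(CNc2nc(SC)nc3ccccc23)cc1`: compound 3 also reaches only the assay limit, > 100000 nM.

The change from compound 2 to compound 1 is a group of 2 heavy atoms (1 carbon, 1 selenium; no ring) in place of a group of 2 heavy atoms (1 carbon, 1 sulfur; no ring), on an aromatic carbon. It produced an at least 1.1-fold lower number from compound 2 to compound 1 (0.07 log units; that floor lies within the scatter), and that step can be read only as a floor because of the limit of > 100000 nM in this assay, at which 2 of the 3 values shown sit. Compound 3 differs from compound 2 by methylsulfanyl in place of hydrogen on an aromatic carbon; here a step that the two limits leave unreadable from compound 2 to compound 3.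

Compound 4 `CSc1ccc(CNc2nc([Se]C)nc3ccccc23)cc1` has not yet been measured in this assay. It differs from compound 3 by a group of 2 heavy atoms (1 carbon, 1 selenium; no ring) in place of a group of 2 heavy atoms (1 carbon, 1 sulfur; no ring), on an aromatic carbon, the same kind of change as that from compound 2 to compound 1, although the surroundings of the changed position are described somewhat differently in the two cases. Since the earlier step was an at least 1.1-fold lower number from compound 2 to compound 1 (0.07 log units; that floor lies within the scatter) and stayed within the scatter, a step of similar size is expected, an at least 1.1-fold lower number from compound 3 to compound 4 (0.04 log units; that floor lies within the scatter). Compound 4 is estimated at 90000 nM, with a likely range from 40000 nM to 200000 nM.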

Compound 4, concentration lethal to 50% of the cells: > 100000 nM
Compound 4 gave a limit, no number; the forecaster's own chance of this, stated with the estimate: 50%; middle value at least 1.1-fold (0.04 log units) away from the limit.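

In this assay compound 4 gives > 100000 nM, which is a limit and not a number. Among these compounds, the steps with a limit on both sides cannot be read, so these compounds show neither that the swap from sulfur to selenium carries over from the core of compound 2 to the core of compound 3 nor that it fails to: the limit of > 100000 nM in this assay, at which 3 of the 4 values shown sit. The one readable new step is an at least 1.1-fold higher number from compound 1 to compound 4 (0.07 log units; that floor lies within the scatter), and it concerns methylsulfanyl in place of hydrogen, not the selenium swap.

The compounds shown leave open how the two groups compare in a compound that gives a number rather than a limit. From the compounds shown here alone, it also remains open whether an amine or a carboxylic acid in place of the methylsulfanyl would give such a number.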